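A Ring Swap That May Undo a Long Half-Life

The source may hold more compounds than are shown below. What is called first, only, known or untested is meant among the compounds shown, and "the series" means these compounds.

In an ADME assay on microsomes from liver (Mus musculus) for metabolic stability (a higher number here means that the compound lasts longer, a lower number that the compound disappears faster), compound 1 (`Cc1nc(C(c2ccc(-c3ccc4cccc(F)c4c3)[nH]c2=O)C(C)C)[nH]c1C`) gives 0.0817 h and compound 2 (`CC(C)C(Cc1noc(=O)[nH]1)c1ccc(-c2ccc3cccc(F)c3c2)[nH]c1=O`) gives 2.78 h as the higher of the two numbers. Compound 3 (`Cc1c[nH]c(C(c2ccc(-c3ccc4cccc(F)c4c3)[nH]c2=O)C(C)C)n1`) has not been measured yet. It differs from compound 2 in one place (a group of 6 heavy atoms (4 carbon, 2 nitrogen; one five-membered aromatic ring with 2 hetero atoms) in place of a group of 7 heavy atoms (3 carbon, 2 nitrogen, 2 oxygen; one five-membered aromatic ring with 3 hetero atoms), on a saturated chain carbon bound to an aromatic carbon and a saturated chain carbon) on a saturated chain carbon bound to an aromatic carbon and a saturated chain carbon. The group that enters, 4-methyl-1H-imidazol-2-yl, is a five-membered aromatic ring with 2 hetero atoms, the same kind of ring that compound 1 carries there. Among the measured compounds shown here, only one measured step bears on this change (a 34-fold higher number from compound 1 to compound 2 (1.53 log units; beyond the scatter)), and it is large and beyond the scatter. A single step is thin evidence, but going back to that kind of ring should undo most of it, so the expected step in this assay is large and downward (a 23-fold lower number from compound 2 to compound 3 (1.36 log units; beyond the scatter)). Compound 3 is expected at 0.12 h (0.05 h to 0.4 h).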

Compound 3, half-life: < 0.0667 h
Compound 3 gave a limit, no number (the forecaster's own chance of this, stated with the estimate: 5%); middle value at least 1.7-fold (0.25 log units) from the limit.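

In this assay, a second five-membered aromatic ring with 2 hetero atoms at this place also falls far short of the group in compound 2, at an at least 41-fold lower number from compound 2 to compound 3 (1.61 log units; beyond the scatter), so the large gap no longer rests on compound 1 alone. Hydrogen in place of methyl on an aromatic carbon gives an at least 1.2-fold lower number from compound 1 to compound 3 (0.08 log units; that floor lies within the scatter), which does not show that this methyl matters. The result for compound 3 is a limit of the assay and not a number, so the full size of both steps stays unknown: the limit of < 0.0667 h in this assay, at which 1 of the 3 values shown sits.

Still open, on these data alone, is which part of the group in compound 2 goes with its longer half-life: the ring, its carbonyl or the chain carbon that carries the ring. A carboxylic acid or a primary amide at this place would help to separate these parts.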